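Ortho chloro added to the weakest imidazole aryl

This account rests on a few compounds, and the source may have more. Where it says the series, first, only, none or still open, it means among the compounds named here.

Compound 3 `COc1cc2c(Oc3ccc(NC(=O)c4cn(-c5ccc(Cl)cc5)cn4)cc3F)ccnc2cc1OCCCN1CCN(C)CC1` gives 1350 nM in a functional assay on HT-29 cells (Homo sapiens) for cytotoxicity, read by MTT assay, with a stated time of 72 h (a lower number here means a stronger inhibitor, a higher number a weaker inhibitor), and stands highest of the three numbers measured there, with compound 2 `COc1cc2c(Oc3ccc(NC(=O)c4cn(-c5cc(C)ccc5C)cn4)cc3F)ccnc2cc1OCCCN1CCN(C)CC1` at 470 nM and compound 1 `COc1cc2c(Oc3ccc(NC(=O)c4cn(-c5ccccc5OC)cn4)cc3F)ccnc2cc1OCCCN1CCN(C)CC1` at 80 nM. Compound 4 `COc1cc2c(Oc3ccc(NC(=O)c4cn(-c5ccc(Cl)cc5Cl)cn4)cc3F)ccnc2cc1OCCCN1CCN(C)CC1` differs from compound 3 by chloro in place of hydrogen on an aromatic carbon. For the measured compounds named here, no measured step adds a single substituent to this ring; the nearest comparisons are a 17-fold higher number from compound 1 to compound 3 (1.23 log units; beyond the scatter) and a 2.9-fold higher number from compound 2 to compound 3 (0.46 log units; beyond the scatter), both reaching compound 3 by removing substituents from the aryl group. Compound 1 and compound 2 both carry a group at the position the new chloro enters, so a moderate decrease in this assay is expected, a 2.3-fold lower number from compound 3 to compound 4 (0.35 log units; beyond the scatter). Compound 4 is therefore estimated at 600 nM, within 200 nM to 2000 nM.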

Compound 4, half-maximal inhibitory concentration: 3050 nM
Compound 4: the middle estimate sits 5.1-fold (0.71 log units) below what was measured, outside the stated range (above it).
By their numbers in this assay, from the lowest: compound 1; then compound 2; then compound 3; then compound 4.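

In this assay, chloro in place of hydrogen ortho to a large group gives a 2.3-fold higher number from compound 3 to compound 4 (0.35 log units; beyond the scatter) and so raises the number, which shows that a substituent at this position does not by itself lower it. The 2,4-dichlorophenyl group also falls behind both earlier aryl groups, with a 6.5-fold higher number from compound 2 to compound 4 (0.81 log units; beyond the scatter) and with a 38-fold higher number from compound 1 to compound 4 (1.58 log units; beyond the scatter) in the same assay. No measurement at hand accounts for this.

From the compounds shown here alone, whether the rise is specific to chloro stays open. So does whether methoxy or an amine entering at this position on 4-chlorophenyl would lower the number.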